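Swapping a Flexible Amine Chain for an Aminomethylphenyl Group

The source may hold more compounds than are shown below. What is called first, only, known or untested is meant among the compounds shown, and "the series" means these compounds.

Of the compounds shown here, two sharing one core have been measured in a functional assay on cells for antagonist activity at C-X-C chemokine receptor type 4 (Homo sapiens), read by fluorescence and calcium flux, with stated times of 25 min and 90 s; a lower number here means a stronger inhibitor, a higher number a weaker inhibitor. Compound 1 `c1ccc2c(c1)CN[C@@H](CN(CCCCNCC1CCOCC1)[C@H]1CCCc3cccnc31)C2` gives 52.9 nM. Compound 2 `c1ccc2c(c1)CN[C@@H](CN(CCCCNC1CCCCC1)[C@H]1CCCc3cccnc31)C2` gives 75.2 nM. The only step between them, a 1.4-fold higher number from compound 1 to compound 2 (0.15 log units; within the scatter), lies within the scatter, so on the numbers shown compound 2 and compound 1 cannot be told apart. Compound 3 `NCc1ccccc1CN(C[C@H]1Cc2ccccc2CN1)[C@H]1CCCc2cccnc21` is not yet measured. It differs from compound 2 in one place: 2-(aminomethyl)phenyl in place of 3-(cyclohexylamino)propyl on a saturated chain carbon bound to an amine nitrogen. Among the measured compounds shown here, no measured step bears on this part of the molecule; the single step recorded swapped only a group on an amine nitrogen and stayed within the scatter. The outcome for compound 3 is therefore open, and a wide range is the honest expectation. Compound 3 is estimated at 100 nM, within a range of 15 nM to 700 nM. The expected step, a 1.3-fold higher number from compound 2 to compound 3 (0.12 log units; within the scatter), carries no firm direction.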

Compound 3, half-maximal inhibitory concentration: 50.8 nM
Compound 3: the middle estimate sits 2.0-fold (0.29 log units) above what was measured, and the stated range covers the measured number.
By their numbers in this assay, from the lowest: compounds 3, 1 and 2 (each within the scatter of the next).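

In this assay, the open-chain 3-(cyclohexylamino)propyl group can be replaced by 2-(aminomethyl)phenyl, which carries an aromatic ring and its amine on a single carbon, and the two compounds still cannot be told apart (a 1.5-fold lower number from compound 2 to compound 3 (0.17 log units; within the scatter)). The same holds against the group carried by compound 1 (a 1.0-fold lower number from compound 1 to compound 3 (0.02 log units; within the scatter)), so at this position three quite different amine-bearing groups give readings within the scatter of one another. No supporting data are available to explain why these groups read alike.

From the compounds shown here alone, it remains open whether the amine in the new group matters at all, which a plain phenyl or a carboxylic acid in its place would test. Going by these compounds, it also remains open whether its place on the ring matters, which 4-(aminomethyl)phenyl would test.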